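Swapping Difluoromethyl for a Carbamate on a Pyridine-Free Core

The source may report more compounds than this note shows. Statements on the series, on what has been measured and on what is new or still open speak of the compounds shown alone.

Of the compounds shown here, two have so far been measured in an ADME assay on microsomes from liver (Homo sapiens) for metabolic stability, read by LC-MS, using NADPH, with a stated time of 10 min, tested at 0.5 uM; a higher number here means that more of the compound is left, a lower number that less of the compound is left. Compound 1, `Cc1cc(-c2ccnc(C(F)F)c2)ncc1OC[C@@](C)(N)CC(C)C`, gives 83%. Compound 2, `CC(=O)Nc1cc(-c2cc(F)c(OC[C@@H](N)CC(C)C)c(F)c2)ccn1`, gives 90%. The two numbers sit close together, and the gap between them is within the usual scatter of this assay, so neither compound can be said to stand above the other.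

Compound 3, `COC(=O)Nc1cc(-c2cc(C)c(OC[C@@](C)(N)CC(C)C)cn2)ccn1`, has not yet been measured. It differs from compound 1 in one place: (methoxycarbonyl)amino in place of difluoromethyl on an aromatic carbon. The group that leaves carries two fluorines on a single carbon, while the group that enters brings a hydrogen-bond donor and two acceptors.

Among the compounds with values here, no step between two measured compounds is available to guide the estimate, so the expectation rests on the two values shown. Both lie high in this assay, and a step like a number 3 percentage points lower from compound 1 to compound 3 (within the scatter) is expected, that is, no change beyond the scatter, because compound 2 gives 90% with a comparable arrangement. Compound 3 is therefore estimated to give about 80%, with a likely range from 60% to 95%.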

Compound 3, percent of the compound remaining: 100%
For compound 3 the middle estimate is 20 percentage points below the measured one; measured number above the stated range.
By their numbers in this assay, from the lowest: compounds 1, 2 and 3 (each within the scatter of the next, the first and the last beyond it).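

In this assay, putting (methoxycarbonyl)amino in place of difluoromethyl on an aromatic carbon, next to the ring nitrogen, comes with a number 17 percentage points higher from compound 1 to compound 3 (beyond the scatter). Within the data shown here, this is the first step in the set that isolates a single position, and it shows that the larger group, with 5 heavy atoms against 3 and with 1 hydrogen-bond donor and 2 hydrogen-bond acceptors where the old group had none, costs nothing in this read-out; compound 3 gives 100%, which leaves no room for any further rise to show. Nothing measured here says why the number moves with this change.

A single swap changes size, atoms and hydrogen-bonding groups all at once, so the compounds shown leave open which of these goes with the step. Going by these compounds, a plain amine or a methoxy group on the same aromatic carbon would help to separate them, and whether the step holds on a core other than that of compound 1 also remains open.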